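Cytotoxicity Outlook for an Isobutylamino Analogue of Compound 2

This account rests on a few compounds, and the source may have more. Where it says the series, first, only, none or still open, it means among the compounds named here.

Compound 1, `CCCCCCCCOc1nc(N)nc2c1ncn2/C=C1/CC1(CO)CO`: in an ADME assay on BCBL1 cells (Homo sapiens) for cytotoxicity, with a stated time of 7 days (a higher number here means that more compound is tolerated, a lower number that less compound is tolerated), compound 1 gives > 20000 nM, which is a limit of the assay and not a number.
Compound 2, `CCCSc1nc(N)nc2c1ncn2/C=C1/CC1(CO)CO`: in this assay compound 2 gives > 20000 nM, again a limit.
Compound 3, `CSc1nc(N)nc2c1ncn2/C=C1/CC1(CO)CO`: in this assay compound 3 gives > 20000 nM, also a limit.

Compound 2 therefore stands at the limit of > 20000 nM in this assay, at which 3 of the 3 values shown sit, and the two other values shown are limits of the same kind. Because of this the steps among the measured compounds cannot be read: a step that the two limits leave unreadable from compound 1 to compound 2, a step that the two limits leave unreadable from compound 1 to compound 3 and a step that the two limits leave unreadable from compound 2 to compound 3 all remain of unknown size.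

The unmeasured compound 4 is `CC(C)CNc1nc(N)nc2c1ncn2/C=C1/CC1(CO)CO`. It differs from compound 2 at the same aromatic carbon that the measured steps touch: isobutylamino in place of propylsulfanyl on an aromatic carbon. Among the measured compounds shown here, the steps that bear on this change are the two that alter the group at that position, from compound 1 to compound 2 and from compound 2 to compound 3, and neither is readable, so no direction of change in this assay can be derived from them. Given that every measured compound sits at the limit, compound 4 is expected to do likewise, with an estimate of 30000 nM in a range from 12000 nM to 100000 nM. The step this estimate means is expected to be a step that the limit leaves unreadable from compound 2 to compound 4, most probably unreadable again.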

Compound 4, half-maximal cytotoxic concentration: > 20000 nM
Compound 4: a limit, no number; the forecaster's own chance of this, stated with the estimate: 80%; the middle value lies beyond the limit too.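

The result for compound 4 gives no readable step to compound 1, compound 2 or compound 3 in this assay, because all four compounds stand at a limit of the assay and not at a number: the limit of > 20000 nM in this assay, at which 4 of the 4 values shown sit.

The compounds shown leave open how far each lies beyond that limit, and so whether octyloxy, propylsulfanyl, methylsulfanyl or isobutylamino on that aromatic carbon makes any difference in this assay.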